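Bromo to 2-methoxyphenyl on the benzylamine of compound 1

The compounds below may be only part of what the source reports. "The series", "measured", "known", "first", "only" and "open" are said of these compounds alone.

Measured compounds:
compound 1 `O=C(O)CCc1ccc(NCc2cccc(Br)c2)cc1` 174 nM
compound 2 `N#Cc1cccc(COc2ccc(CCC(=O)O)cc2)c1` 525 nM

In a functional assay on 1321-N1 cells for agonist activity at Free fatty acid receptor 1 (Homo sapiens), read by calcium flux (a lower number here means that less compound is needed, a higher number that more compound is needed for the effect), compound 1 gives 174 nM, the lowest of the two numbers recorded. Compound 2 gives 525 nM; the gap to compound 1 lies beyond the usual scatter, and these two differ in more than one place, so no single structural step can be read from them.

Compound 3 `COc1ccccc1-c1cccc(CNc2ccc(CCC(=O)O)cc2)c1` is not yet measured. It changes one place relative to compound 1: 2-methoxyphenyl in place of bromo on an aromatic carbon, set on an aromatic carbon of a six-membered aromatic ring of carbon only, meta to a large group. Within the data shown here, no measured pair in this small set contains such a step, so its size is estimated rather than read from data. The expectation is a step from compound 1 to compound 3 of a 2.9-fold lower number from compound 1 to compound 3 (0.46 log units; beyond the scatter) in this assay, a move to a lower number that should exceed the scatter but remain moderate. For compound 3 the estimated value in this assay is 60 nM, with a range from 15 nM to 250 nM.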

Compound 3, half-maximal effective concentration: 69.2 nM
The estimate for compound 3 lay 1.2-fold (0.06 log units) below the measured number, and the stated range covers the measured number.
By their numbers in this assay, from the lowest: compound 3; then compound 1; then compound 2.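

In this assay, this aromatic carbon, meta to a large group, accepts much more than the bromo of compound 1: exchanging that single bromine for 2-methoxyphenyl adds a six-membered aromatic ring of carbon only and a hydrogen-bond acceptor, and gives a 2.5-fold lower number from compound 1 to compound 3 (0.40 log units; beyond the scatter). Among these compounds, this is the first single-place step, and it shows that growth at this position from 1 heavy atom to 8 heavy atoms moves the number down rather than up, by a modest step that lies beyond the scatter. Nothing available explains the size or direction of this step, so it stands as an observation only.

From the compounds shown here alone, it remains open whether the added ring alone or its methoxy group carries the step, and a plain phenyl or a pyridine ring at the same carbon would help to separate the two. Going by these compounds, it also remains open whether 2-methoxyphenyl gives a similar step on the core of compound 2, which differs from compound 1 in more than one place.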